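The source may report more compounds than this note shows. Statements on the series, on what has been measured and on what is new or still open speak of the compounds shown alone.

Compound 1 `COc1cc(-c2nnc(SCc3ccc(C)cc3)o2)ccc1O` and compound 2 `COc1cc(-c2nnc(SCc3ccc(F)cc3)o2)ccc1O` share one core and differ only in a single group on the outer aromatic ring. In an ADME assay on cells (Mus musculus, strain BALB/c) for cytotoxicity, read by MTT assay, with a stated time of 24 h (a higher number here means that more compound is tolerated, a lower number that less compound is tolerated), compound 1 gives 549000 nM and compound 2 gives 685000 nM; the step of a 1.2-fold higher number from compound 1 to compound 2 (0.10 log units; within the scatter) is too small to separate the two, so compound 2 stands level with compound 1 rather than apart from it. Compound 3 `COc1cc(-c2nnc(SCc3ccc(F)cc3)o2)ccc1OCc1ccc(F)cc1` is the next step from compound 2: 4-fluorobenzyl in place of hydrogen on an oxygen on an aromatic ring. Among the measured compounds shown here, the only measured step, from compound 1 to compound 2, swaps one small group on an aromatic carbon and changes little, but it does not probe the hydroxy group that is altered here, so it says almost nothing about the size or direction of the new step. The expectation for compound 3 is therefore a step of a 1.4-fold lower number from compound 2 to compound 3 (0.14 log units; within the scatter) close to none, with a wide range. Compound 3 is estimated at 500000 nM, between 150000 nM and 1500000 nM.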

Compound 3, half-maximal cytotoxic concentration: 153000 nM
Compound 3: the middle estimate sits 3.3-fold (0.51 log units) above what was measured, and the stated range covers the measured number.
By their numbers in this assay, from the lowest: compound 3; then compounds 1 and 2 (each within the scatter of the next).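

In this assay the oxygen on the aromatic ring proves to be a place where a change can be read: hydroxy to (4-fluorobenzyl)oxy gives a 4.5-fold lower number from compound 2 to compound 3 (0.65 log units; beyond the scatter) and this modest step lies beyond the scatter. The earlier swap of one small group on an aromatic carbon gave no such separation, so this is the first change shown that moves the number clearly, with less compound tolerated after it. Nothing available bears on the reason for this step.

As far as these compounds go, it remains open whether the step follows from losing the hydrogen on that oxygen or from gaining the whole 4-fluorobenzyl group. A methyl or an unsubstituted benzyl on the same oxygen would help separate these two readings, and a longer chain ending in an amine would test a different kind of group there.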